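From pyrrolidin-2-yl to piperidin-4-yl on a shared core

A few compounds are considered here, and "the series" means these few. Any claim that something is new, unique, unknown or untested is made for them only; others in the source may bear on it.

Compound 1 `COc1ccc(-c2noc(-c3ccccc3)n2)cc1OC1CCCC1`: > 1000000 nM
Compound 2 `COc1ccc(-c2noc(-c3ccncc3)n2)cc1OC1CCCC1`: > 1000000 nM
Compound 3 `COc1ccc(-c2noc(C3CCCN3)n2)cc1OC1CCCC1`: 242000 nM

In a functional assay on DU-145 cells (Homo sapiens) for antiproliferative activity, read by MTT assay, with a stated time of 24 h (a higher number here means a weaker inhibitor, a lower number a stronger inhibitor), compound 1 gives only a limit, > 1000000 nM. Compound 2 also gives only a limit, > 1000000 nM. Compound 3, at 242000 nM, is the only one of the three with a number, and so stands as the single measured reference point.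

Compound 4 `COc1ccc(-c2noc(C3CCNCC3)n2)cc1OC1CCCC1` alters one group of compound 3: piperidin-4-yl in place of pyrrolidin-2-yl on an aromatic carbon. Three measured steps surround this change. Among the compounds with values here, the first is a step that the two limits leave unreadable from compound 1 to compound 2. The other two are an at least 4.1-fold lower number from compound 1 to compound 3 (0.61 log units; beyond the scatter) and an at least 4.1-fold lower number from compound 2 to compound 3 (0.61 log units; beyond the scatter), and each gives only a lower bound on its size. Both of those exchange an aromatic group for pyrrolidin-2-yl, whereas compound 4 keeps a non-aromatic ring. None of the three steps exchanges one non-aromatic ring for another, so no step beyond the scatter is expected in this assay, and no direction is favoured.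

For compound 4 the estimate is 220000 nM, with an expected range from 80000 nM to 650000 nM. This estimate means an expected 1.1-fold lower number from compound 3 to compound 4 (0.04 log units; within the scatter).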

Compound 4, half-maximal inhibitory concentration: 57 nM
Compound 4: middle estimate off by 3900-fold (3.59 log units), on the high side; measured number below the stated range.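

Piperidin-4-yl in place of pyrrolidin-2-yl gives a 4200-fold lower number from compound 3 to compound 4 (3.63 log units; beyond the scatter) in this assay, so this position distinguishes sharply between two non-aromatic rings, something the earlier compounds, which exchanged only aromatic groups and pyrrolidin-2-yl, could not show. Against the aromatic groups, piperidin-4-yl gives an at least 17000-fold lower number from compound 2 to compound 4 (4.24 log units; beyond the scatter) and an at least 17000-fold lower number from compound 1 to compound 4 (4.24 log units; beyond the scatter). Those two sizes are only lower bounds because compound 1 and compound 2 each give a limit rather than a number: the limit of > 1000000 nM in this assay, at which 2 of the 4 values shown sit.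

The step from compound 3 to compound 4 changes a five-membered ring to a six-membered ring and also moves the ring nitrogen relative to the core, and the compounds shown do not separate these two changes. They also leave open how a piperidin-3-yl group, an N-methylpiperidin-4-yl group or an open-chain amine would read at this position.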